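Swapping a bromo for hydrogen in compound 1

This account rests on a few compounds, and the source may have more. Where it says the series, first, only, none or still open, it means among the compounds named here.

In an ADME assay on BAEC cells (Bos taurus) for cytotoxicity, read by MTT assay, with a stated time of 2 days (on this read-out lower numbers stand for stronger inhibition and higher numbers for weaker inhibition), compound 1 `COC1=C(Br)C(=O)[C@]2(C=C1Br)CO2` gives 161000 nM. Compound 3 `COC1=C(Br)C(=O)[C@]2(C=C1)CO2` gives 11000 nM, which leaves compound 1 with the higher of the two exact numbers in this small set. Compound 2 `COC1=C(Br)C(=O)[C@@]2(CO2)C(OC)=C1Br` gives > 15000 nM, and this is a limit, not an exact number.

Compound 4 `COC1=CC(=O)[C@]2(C=C1Br)CO2` has not yet been measured. It differs from compound 1 by a single swap, hydrogen in place of bromo on a double-bonded ring carbon.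

Two measured steps start from compound 1. The first, a step that the limit leaves unreadable from compound 1 to compound 2, says nothing useful about size. The second is the closer guide, since compound 3 also carries hydrogen in place of bromo on a double-bonded ring carbon, though not on the same carbon as in compound 4. That swap gives a 15-fold lower number from compound 1 to compound 3 (1.17 log units; beyond the scatter). For the measured compounds named here, it is only one example at a different carbon, so the same direction seems likely, with a smaller size and wide uncertainty. The estimated change is a 4.6-fold lower number from compound 1 to compound 4 (0.66 log units; beyond the scatter). For compound 4 the expected value in this assay is 35000 nM, with an estimated range of 8000 nM to 160000 nM.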

Compound 4, half-maximal inhibitory concentration: > 22000 nM
Compound 4 gave a limit, no number; the forecaster's own chance of this, stated with the estimate: 25%; the middle value lies beyond the limit too.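

In this assay compound 4 gives > 22000 nM, which is a limit and not a number. The step from compound 1 to compound 4 therefore cannot be read. The compounds shown leave open how far compound 4 lies from compound 1, and whether hydrogen in place of bromo shifts the number similarly on either carbon.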